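The source may hold more compounds than are shown below. What is called first, only, known or untested is meant among the compounds shown, and "the series" means these compounds.

Measured compounds:
- compound 1 `COc1ccc(N2C(=O)COc3ccc(-c4cnc(OC)c(NS(=O)(=O)c5ccc(F)cc5)c4)cc32)cc1` — 13400 nM
- compound 2 `O=C1COc2ccc(-c3cnc4ccccc4c3)cc2N1c1ccc(Cl)cc1` — 36100 nM
- compound 3 `CC(C)N1C(=O)COc2ccc(-c3cnc(Cl)c(NS(=O)(=O)c4ccc(F)cc4)c3)cc21` — 18900 nM

In a functional assay on HCT-116 cells (Homo sapiens) for antiproliferative activity, read by MTT assay, with a stated time of 72 h (a lower number here means a stronger inhibitor, a higher number a weaker inhibitor), compound 1 gives 13400 nM, the lowest of the three numbers. Compound 3 gives 18900 nM, and that gap to compound 1 lies within the usual scatter, so the two cannot be ordered. Compound 2 gives 36100 nM, a higher number than compound 1 by a gap beyond the scatter. Within the data shown here, no pair of these three differs in a single place, so no isolated step is available from the measured set.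

Compound 4 `COc1ncc(-c2ccc3c(c2)NC(=O)CO3)cc1NS(=O)(=O)c1ccc(F)cc1` is not yet measured. Against compound 1 it carries one change: hydrogen in place of 4-methoxyphenyl on an amide-type nitrogen in a ring. Nothing measured here bears on this change, since the other two compounds each differ from compound 1 in more than one place. For the step from compound 1 to compound 4 in this assay a step of the size a 1.5-fold higher number from compound 1 to compound 4 (0.17 log units; within the scatter) is expected, at most a small move toward a higher number, and likely none beyond the scatter. Compound 4 is estimated at 20000 nM, with a range of 7000 nM to 60000 nM.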

Compound 4, half-maximal inhibitory concentration: 24900 nM
For compound 4 the middle estimate is 1.2-fold (0.10 log units) below the measured one; the range from low to high includes it.
By their numbers in this assay, from the lowest: compounds 1, 3, 4 and 2 (each within the scatter of the next, the first and the last beyond it).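

In this assay, among these compounds, the amide-type nitrogen in the ring now has its only single-place comparison, and hydrogen in place of 4-methoxyphenyl gives a 1.9-fold higher number from compound 1 to compound 4 (0.27 log units; within the scatter). At this position, the loss of all 8 heavy atoms of that group, including its six-membered aromatic ring, therefore produces no change beyond the scatter. No measurement on hand offers an explanation for this step.

As far as these compounds go, it remains open whether any group on this nitrogen can take the number clearly below those of compound 1 and compound 4; a benzyl group or an aminoethyl chain there would test this. Compound 2 and compound 3 each differ from compound 1 in more than one place, so the contributions of the other parts of the series cannot be separated.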